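A dimethylphenyl swap in a growth-inhibition series

This account rests on a few compounds, and the source may have more. Where it says the series, first, only, none or still open, it means among the compounds named here.

In a functional assay on A549 cells (Homo sapiens) for antiproliferative activity, read by spectrophotometry, with a stated time of 2 days (on this read-out lower numbers stand for stronger inhibition of growth and higher numbers for weaker inhibition of growth), compound 1 `COc1cc(Nc2ncc(C(F)(F)F)c(N3Cc4cccc(N(C)S(C)(=O)=O)c4C3)n2)c(OC)cc1Cl` gives 7300 nM. Compound 2 `CN(c1cccc2c1CN(c1nc(Nc3ccc(Nc4ccccc4)cc3)ncc1C(F)(F)F)C2)S(C)(=O)=O` gives 6200 nM, which lies within the scatter of the value for compound 1. Compound 3 `CN(c1cccc2c1CN(c1nc(Nc3cc(C(F)(F)F)cc(C(F)(F)F)c3)ncc1C(F)(F)F)C2)S(C)(=O)=O` reaches only a limit, > 30000 nM.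

Compound 4 `Cc1ccc(Nc2ncc(C(F)(F)F)c(N3Cc4cccc(N(C)S(C)(=O)=O)c4C3)n2)c(C)c1` carries 2,4-dimethylphenyl in place of the 4-chloro-2,5-dimethoxyphenyl of compound 1 on a nitrogen on an aromatic ring (2,4-dimethylphenyl in place of 4-chloro-2,5-dimethoxyphenyl on a nitrogen on an aromatic ring). Among the compounds with values here, no measured pair isolates this change, so the expectation rests on the closeness of compound 1 to compound 2 at 6200 nM. The expected step of a 1.1-fold higher number from compound 1 to compound 4 (0.04 log units; within the scatter) stays within the scatter, with no firm direction. Compound 4 is estimated at 8000 nM, with an expected range from 3000 nM to 25000 nM.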

Compound 4, concentration for 50% growth inhibition: 20700 nM
Compound 4: the middle estimate sits 2.6-fold (0.41 log units) below what was measured, within the range that was stated.
By their numbers in this assay, from the lowest: compounds 2 and 1 (each within the scatter of the next); then compound 4. At a limit, above all of these: compound 3.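

Within the data shown here, compound 1 and compound 4 give the first pair that differs in one place, and in this assay the swap of 4-chloro-2,5-dimethoxyphenyl for 2,4-dimethylphenyl on the nitrogen gives a modest loss of growth inhibition (a 2.8-fold higher number from compound 1 to compound 4 (0.45 log units; beyond the scatter)). The group at this position therefore affects the read-out, and the loss lies beyond the usual scatter. Nothing shown accounts for this step.

The two groups differ in several atoms at once, and the compounds shown do not separate the chlorine from the methoxy groups. As far as these compounds go, how an amine or a carboxylic acid on this phenyl ring would read also remains open.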